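Urea series: swapping the aryl amine substituent

This account rests on a few compounds, and the source may have more. Where it says the series, first, only, none or still open, it means among the compounds named here.

Measured so far:
Compound 1, `COc1cc(NC(=O)Nc2cc(Nc3ccc(C(C)(C)C)cc3)ncn2)cc(OC)c1`: 32.7%
Compound 2, `COc1cc(NC(=O)Nc2cc(Nc3ccc(C)c(C)c3)ncn2)cc(OC)c1`: 45.7%
Compound 3, `CCc1cccc(Nc2cc(NC(=O)Nc3cc(OC)cc(OC)c3)ncn2)c1`: 52.6%

All three share one core and differ only in the aryl group on a nitrogen on an aromatic ring. In a functional assay on HCC827 cells (Homo sapiens) for inhibition, read by MTT assay, with a stated time of 48 h, tested at 10 uM (on this read-out higher numbers stand for more inhibition at the one concentration tested (going by the name of the read-out) and lower numbers for less inhibition), compound 3 gives the highest of the three numbers; its gap to compound 2 is within the scatter, while a number 19.9 percentage points higher from compound 1 to compound 3 (beyond the scatter) and a number 13 percentage points higher from compound 1 to compound 2 (beyond the scatter) lie beyond it. Compound 4, `COc1cc(NC(=O)Nc2cc(Nc3ccc(Br)cc3OC)ncn2)cc(OC)c1`, changes compound 3 by 4-bromo-2-methoxyphenyl in place of 3-ethylphenyl on a nitrogen on an aromatic ring. Within the data shown here, no measured step covers this exact swap; the two steps beyond the scatter both involve leaving 4-(tert-butyl)phenyl, and the step of a number 6.9 percentage points higher from compound 2 to compound 3 (within the scatter) is small. A modest drop or no change is therefore expected, as a number 7.6 percentage points lower from compound 3 to compound 4 (within the scatter). Compound 4 is estimated at 45%, between 30% and 60%.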

Compound 4, a percentage reported as inhibition, at one concentration (the size of the read-out at that concentration, not a potency): 57.7%
Compound 4: middle estimate off by 12.7 percentage points, on the low side, within the range that was stated.
By their numbers in this assay, from the lowest: compound 1; then compounds 2, 3 and 4 (each within the scatter of the next, the first and the last beyond it).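

At this place, a ring carrying both oxygen and bromine reads no differently from 3-ethylphenyl, with a number 5.1 percentage points higher from compound 3 to compound 4 (within the scatter) in this assay. Unlike 3-ethylphenyl, however, 4-bromo-2-methoxyphenyl separates from both other groups, with a number 12 percentage points higher from compound 2 to compound 4 (beyond the scatter) and a number 25 percentage points higher from compound 1 to compound 4 (beyond the scatter). No measurement available here explains these differences. Still open, from the compounds shown here alone, is what the bromine and the methoxy each contribute alone, since they enter together. Also open, going by these compounds, is how a phenyl ring bearing an amine or a carboxylic acid would read at this place.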